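The compounds below may be only part of what the source reports. "The series", "measured", "known", "first", "only" and "open" are said of these compounds alone.

Compound 1 `O=C(CCSc1nc2cc(F)ccc2o1)N1CCCC1`: 5.2 mL/min/g
Compound 2 `O=C(CCNc1nc2cc(Cl)ccc2o1)N1CCCC1`: 2.3 mL/min/g

Within the data shown here, in an ADME assay on microsomes from liver (Homo sapiens) for metabolic stability, read by LC-MS, using NADPH, with a stated time of 45 min, tested at 0.5 uM (a lower number here means slower removal, a higher number faster removal of the compound), compound 1 gives 5.2 mL/min/g, the higher of the two numbers measured so far. Compound 2 gives 2.3 mL/min/g, and the gap between the two values lies beyond the usual scatter. Compound 3 `COc1ccc2oc(SCCC(=O)N3CCCC3)nc2c1` has not yet been measured. It differs from compound 1 in one place: methoxy in place of fluoro on an aromatic carbon. Among the measured compounds shown here, no pair of measured compounds differing in a single place is available, so the effect of this change rests on expectation alone. A modest rise is expected, a 1.5-fold higher number from compound 1 to compound 3 (0.19 log units; within the scatter), close to the edge of the scatter. Compound 3 is therefore estimated at 8 mL/min/g, with a range from 4 mL/min/g to 16 mL/min/g.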

Compound 3, intrinsic clearance in a liver preparation (reported as CLH), per the amount of preparation that the assay uses: 6.1 mL/min/g
Beside the measured number, compound 3's estimate is 1.3-fold (0.12 log units) above it; the range from low to high includes it.
By their numbers in this assay, from the lowest: compound 2; then compounds 1 and 3 (each within the scatter of the next).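

In this assay, among these compounds, methoxy in place of fluoro on this aromatic carbon gives a 1.2-fold higher number from compound 1 to compound 3 (0.07 log units; within the scatter) and so provides the first comparison of compounds differing in one place. The step stays within the scatter, so this read-out does not separate the two groups at this position, even though methoxy brings a hydrogen-bond acceptor that fluoro lacks. No measured evidence here bears on the reason for this result. On these data alone, whether a nitrile or an amine on the same carbon would also stay within the scatter remains open. So does whether the same change would behave alike in a compound with a different chain.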